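A few compounds are considered here, and "the series" means these few. Any claim that something is new, unique, unknown or untested is made for them only; others in the source may bear on it.

Compound 3 `CC(C)(C)n1cc2c(n1)C(=O)CC1(CCN(C(=O)c3cc(N4CCNCC4)nc4ccccc34)CC1)O2` sits at > 10000 nM in a functional assay on A549 cells (Homo sapiens) for inhibition, read by MTT assay, with a stated time of 72 h (on this read-out higher numbers stand for weaker inhibition and lower numbers for stronger inhibition), which is a limit of the assay and not a number (the limit of > 10000 nM in this assay, at which 1 of the 3 values shown sits). In this assay, compound 1 `Cc1ccc(-c2cc(C(=O)N3CCC4(CC3)CC(=O)c3nn(C(C)(C)C)cc3O4)c3ccccc3n2)cc1` gives 5300 nM and compound 2 `CN(C)c1ccc(-c2cc(C(=O)N3CCC4(CC3)CC(=O)c3nn(C(C)(C)C)cc3O4)c3ccccc3n2)cc1` gives 1150 nM. Compound 4 `CC(C)Oc1cc(C(=O)N2CCC3(CC2)CC(=O)c2nn(C(C)(C)C)cc2O3)c2ccccc2n1` has isopropoxy in place of piperazin-1-yl on an aromatic carbon next to the ring nitrogen: isopropoxy in place of piperazin-1-yl on an aromatic carbon. Among the compounds with values here, no measured compound carries isopropoxy, so only the steps that introduced piperazin-1-yl bear on this change: an at least 1.8-fold higher number from compound 1 to compound 3 (0.27 log units; that floor lies within the scatter), and an at least 8.6-fold higher number from compound 2 to compound 3 (0.93 log units; beyond the scatter). Reversing that exchange suggests a small move towards a lower number, so the expected step is an at least 1.4-fold lower number from compound 3 to compound 4 (0.15 log units; that floor lies within the scatter), which may not clear the scatter. For compound 4 the estimated value is 7000 nM, with an expected range of 2500 nM to 20000 nM.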

Compound 4, half-maximal inhibitory concentration: > 10000 nM
Compound 4 ended at the assay's limit; the forecaster's own chance of this, stated with the estimate: 35%; at least 1.4-fold (0.15 log units) between middle value and limit.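

In this assay, compound 4 sits at a limit of the assay and not at a number, and since compound 3 does too, the step between them cannot be read: the limit of > 10000 nM in this assay, at which 2 of the 4 values shown sit. At this position, isopropoxy in place of 4-(dimethylamino)phenyl gives an at least 8.6-fold higher number from compound 2 to compound 4 (0.93 log units; beyond the scatter), and isopropoxy in place of 4-methylphenyl gives an at least 1.8-fold higher number from compound 1 to compound 4 (0.27 log units; that floor lies within the scatter). Among these four compounds, only the two carrying a substituted phenyl here give a number.

From the compounds shown here alone, it remains open whether a pyridine ring or a plain amino group at this position would give a number. Going by these compounds, how far compound 3 and compound 4 lie past their limits also remains open.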